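From Hydroxy to Bromo on the Aryl Hydrazide

This account rests on a few compounds, and the source may have more. Where it says the series, first, only, none or still open, it means among the compounds named here.

Compound 1 `C/C(=N\NC(=O)c1ccncc1)c1cnccn1`: 1.2
Compound 2 `C/C(=N\NC(=O)c1cccs1)c1cnccn1`: 2.6
Compound 3 `C/C(=N\NC(=O)c1ccc(O)cc1)c1cnccn1`: 1.9

In a physicochemical assay for lipophilicity (a higher number here means a more lipophilic compound, a lower number a more polar compound), compound 3 gives 1.9, the second highest of the three numbers; compound 1 stands lower at 1.2, and compound 2 stands higher at 2.6. Compound 4 `C/C(=N\NC(=O)c1ccc(Br)cc1)c1cnccn1` differs from compound 3 in one place: bromo in place of hydroxy on an aromatic carbon. Going by the values given here, the only measured step, a number 1.40 log units higher from compound 1 to compound 2 (beyond the scatter), exchanges one ring for another and bears on this change only loosely; no measured pair exchanges a hydroxy or a bromo, so the expectation rests on the change itself. Compound 4 is expected to move upward in this assay by a step of a number 1.50 log units higher from compound 3 to compound 4 (beyond the scatter), beyond the scatter. Compound 4 is estimated at 3.4, with a range from 2.9 to 3.9.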

Compound 4, partition coefficient: 2.9
Compound 4: the middle estimate sits 0.50 log units above what was measured, and the stated range covers the measured number.
By their numbers in this assay, from the lowest: compound 1; then compound 3; then compounds 2 and 4 (each within the scatter of the next).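

Bromo in place of hydroxy on this aromatic carbon gives a number 1.00 log units higher from compound 3 to compound 4 (beyond the scatter) in this assay. This is the only measured pair shown that keeps the six-membered aromatic ring of carbon only and exchanges a single group on it, so it gives this position a measured step of its own, apart from the exchange of one ring for another. No measurement at hand explains the size or direction of this step.

Where an amine, a carboxylic acid or chloro would place a compound at this aromatic carbon remains open. As far as these compounds go, it is also open whether bromo in place of hydroxy would give a similar step on a different ring.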